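Swapping Bromine for Two Fluorines on the Aryl Ketone

A few compounds are considered here, and "the series" means these few. Any claim that something is new, unique, unknown or untested is made for them only; others in the source may bear on it.

Three closely related compounds share one core and differ only in the ring attached to the carbonyl carbon. In an ADME assay on Vero cells (Chlorocebus sabaeus) for cytotoxicity, read by resazurin assay, with a stated time of 72 h (a higher number here means a weaker inhibitor, a lower number a stronger inhibitor), compound 1 `O=C(CCN1CCN(c2ccc(F)cc2)CC1)c1ccccc1` gives 13400 nM. Compound 2 `Cc1ccc(C(=O)CCN2CCN(c3ccc(F)cc3)CC2)cc1` gives 55400 nM in this assay, and compound 3 `O=C(CCN1CCN(c2ccc(F)cc2)CC1)c1ccc(Br)cc1` gives 99500 nM. Compound 3 has the highest number of the three: it stands above compound 1 by a 7.4-fold higher number from compound 1 to compound 3 (0.87 log units; beyond the scatter), but is separated from compound 2 only by a 1.8-fold higher number from compound 2 to compound 3 (0.25 log units; within the scatter). Compound 4 `O=C(CCN1CCN(c2ccc(F)cc2)CC1)c1ccc(F)c(F)c1` has not yet been measured. It differs from compound 3 in a single way: 3,4-difluorophenyl in place of 4-bromophenyl on a carbonyl carbon. Within the data shown here, no measured step introduces fluorine onto this ring, so the closest guides are the two steps that replaced hydrogen on an aromatic carbon, a 4.1-fold higher number from compound 1 to compound 2 (0.62 log units; beyond the scatter) and a 7.4-fold higher number from compound 1 to compound 3 (0.87 log units; beyond the scatter), both of which raised the number by a modest amount. Compound 4 is therefore expected to land between compound 1 and compound 3, closer to compound 3. The expected step is a 2.2-fold lower number from compound 3 to compound 4 (0.34 log units; beyond the scatter), which would likely sit within the scatter. For compound 4 the estimated value in this assay is 45000 nM, with a range from 15000 nM to 120000 nM.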

Compound 4, half-maximal inhibitory concentration: 385000 nM
The estimate for compound 4 lay 8.6-fold (0.93 log units) below the measured number, and the stated range ends below it.
By their numbers in this assay, from the lowest: compound 1; then compounds 2 and 3 (each within the scatter of the next); then compound 4.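

In this assay, among these compounds, the ring on the carbonyl carbon proves able to move the number much further than the earlier compounds showed: the change to 3,4-difluorophenyl gives a 3.9-fold higher number from compound 3 to compound 4 (0.59 log units; beyond the scatter) and a 6.9-fold higher number from compound 2 to compound 4 (0.84 log units; beyond the scatter) and also a 29-fold higher number from compound 1 to compound 4 (1.46 log units; beyond the scatter) which is the only large step in this set. Compound 2 and compound 3 lay within the scatter of each other, so 4-methylphenyl and 4-bromophenyl could not be told apart, whereas 3,4-difluorophenyl stands clearly apart from both, so this position has not yet reached a ceiling at their level. Every substituted ring here carries a higher number than the plain phenyl of compound 1, with no compound going against that, yet no measurement shown explains why the difluorinated ring goes furthest.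

With both fluorines entering together, the compounds shown cannot say whether one of them carries most of the rise or whether the pair is needed, a question that a single-fluorine ring such as 4-fluorophenyl would address. They also leave open how this position would respond to a quite different group on the ring, such as a nitrile, a methoxy group or an amine.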